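The source may report more compounds than this note shows. Statements on the series, on what has been measured and on what is new or still open speak of the compounds shown alone.

Measured so far, in a functional assay for inhibition of cysteinyl leukotriene receptor 1 (Cavia porcellus); on this read-out higher numbers stand for an effect only at larger amounts of compound and lower numbers for an effect already at smaller amounts:
Compound 1 `CCC(C)CNC(=O)c1ccc2c(c1)c(Cc1ccc(C(=O)NS(=O)(=O)c3ccccc3C)cc1OC)cn2C` gives 20 umol/kg.
Compound 2 `COc1cc(C(=O)NS(=O)(=O)c2ccccc2C)ccc1Cc1cn(C)c2ccc(C(=O)NCC3CCCC3)cc12` gives 19.2 umol/kg.
Compound 3 `COc1cc(C(=O)NS(=O)(=O)c2ccccc2C)ccc1Cc1cn(C)c2ccc(C(=O)NCC(C)CC(F)(F)F)cc12` gives 1.44 umol/kg.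

Compound 2 holds the second highest of these three numbers; its nearest neighbour is compound 1, a 1.0-fold lower number from compound 1 to compound 2 (0.02 log units; within the scatter), and its furthest is compound 3, a 13-fold lower number from compound 2 to compound 3 (1.12 log units; beyond the scatter). Compound 4 `CCC(CNC(=O)c1ccc2c(c1)c(Cc1ccc(C(=O)NS(=O)(=O)c3ccccc3C)cc1OC)cn2C)CC(F)(F)F` differs from compound 2 by 1-(2,2,2-trifluoroethyl)propyl in place of cyclopentyl on a saturated chain carbon bound to an amide-type nitrogen. The entering group closely resembles the 3,3,3-trifluoro-1-methylpropyl of compound 3, so two measured steps bear on this change: a 13-fold lower number from compound 2 to compound 3 (1.12 log units; beyond the scatter) and a 14-fold lower number from compound 1 to compound 3 (1.14 log units; beyond the scatter), both large and both toward a lower number. The expected step is therefore an 11-fold lower number from compound 2 to compound 4 (1.03 log units; beyond the scatter), large and in the same direction. Compound 4 is estimated at 1.8 umol/kg, with a range from 0.7 umol/kg to 5 umol/kg.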

Compound 4, dose for half-maximal effect: 2.64 umol/kg
For compound 4 the middle estimate is 1.5-fold (0.17 log units) below the measured one; the measured number falls inside the stated range.
By their numbers in this assay, from the lowest: compounds 3 and 4 (each within the scatter of the next); then compounds 2 and 1 (each within the scatter of the next).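

In this assay 1-(2,2,2-trifluoroethyl)propyl in place of cyclopentyl gives a 7.3-fold lower number from compound 2 to compound 4 (0.86 log units; beyond the scatter) and trifluoromethyl in place of hydrogen gives a 7.6-fold lower number from compound 1 to compound 4 (0.88 log units; beyond the scatter) so a second chain carrying trifluoromethyl also stands well under the chains without fluorine. Methyl in place of hydrogen on that chain gives a 1.8-fold higher number from compound 3 to compound 4 (0.26 log units; within the scatter) which lies within the scatter, so this added carbon makes no readable difference here. As far as these compounds go, whether a chain ending in a nitrile or a hydroxyl would keep such low numbers remains open. No measured evidence explains why these chains differ.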